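Loss of two methyls at the cyanoguanidine terminus of compound 1

The source may report more compounds than this note shows. Statements on the series, on what has been measured and on what is new or still open speak of the compounds shown alone.

Compound 1, `CN(C)/C(=N/CCCCn1nc(-c2ccccc2)ccc1=O)NC#N`: 80.7%
Compound 2, `CC/N=C(/NC#N)NCCCn1nc(C)ccc1=O`: 34.5%
Compound 3, `C#CCN/C(=N/CCCCn1nc(-c2ccccc2)ccc1=O)NC#N`: -12.9%

In a functional assay on the whole organism with Rattus norvegicus as the target, at a dose of 100 mg/kg (a lower number here means less inhibition, a higher number more inhibition at the dose given (going by the name of the read-out)), compound 1 stands highest of the three, with compound 2 and compound 3 both beyond the scatter below it. Compound 4, `N#CNC(=N)NCCCCn1nc(-c2ccccc2)ccc1=O`, has not yet been measured. It differs from compound 1 as follows: a group of 6 heavy atoms (2 carbon, 4 nitrogen; no ring) in place of a group of 8 heavy atoms (4 carbon, 4 nitrogen; no ring), on a saturated chain carbon, four bonds along the chain from an aromatic nitrogen. Within the data shown here, only one measured step touches the same part of the molecule, the change from compound 1 to compound 3, where propargylamino replaced dimethylamino on the carbon with a double bond to nitrogen; that step was a number 93.6 percentage points lower from compound 1 to compound 3 (beyond the scatter), a large fall. Among the measured compounds shown here, compound 2 carries several differences at once and no single step to it is available, so only its own value is known. For the measured compounds named here, because of a number 93.6 percentage points lower from compound 1 to compound 3 (beyond the scatter), a change at this position is expected to cost inhibition, though the present change is smaller than the one leading to compound 3, so the expected step is a number 35.7 percentage points lower from compound 1 to compound 4 (beyond the scatter), downward but less severe. Compound 4 is therefore estimated at 45%, in a range from 5% to 85%.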

Compound 4, a percentage reported as inhibition, in the whole organism at one dose (the size of the read-out at that dose, not a potency): 61.2%
The estimate for compound 4 lay 16.2 percentage points below the measured number, within the range that was stated.
By their numbers in this assay, from the lowest: compound 3; then compound 2; then compound 4; then compound 1.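

In this assay, the change gives a number 19.5 percentage points lower from compound 1 to compound 4 (beyond the scatter), so the two methyls of compound 1 do matter at this terminus, but losing them costs far less than the swap to propargylamino, a number 93.6 percentage points lower from compound 1 to compound 3 (beyond the scatter). The earlier compounds shown here showed only a collapse on changing this end; the new result shows that the end group can be stripped of its carbon substituents and still retain substantial inhibition, with compound 4 at 61.2% and compound 3 at -12.9%. Nothing available explains why these two changes differ so much in size.

On these data alone, it remains open where a methylamino group, carrying a single methyl, would fall relative to compound 1 and compound 4. As far as these compounds go, it is equally open whether a morpholino group, which ties the terminal nitrogen into a ring, would hold inhibition or lose it.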